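The compounds below may be only part of what the source reports. "The series", "measured", "known", "first", "only" and "open" are said of these compounds alone.

In a physicochemical assay for acid dissociation, compound 1 `Cc1cc(-c2ccnc3[nH]nc(C(F)(F)F)c23)cc(C2(CN)CCC2)c1` gives 8.8 and compound 2 `NCC1(c2cccc(-c3ccnc4[nH]nc(C(F)(F)F)c34)c2)CCC1` gives 8.8, so the two stand level. Compound 3 `Cc1cc(-c2ccnc3[nH]nc(C(F)(F)F)c23)cc(C2(CN)COC2)c1` is still unmeasured and differs from compound 1 in one place: 3-(aminomethyl)oxetan-3-yl in place of 1-(aminomethyl)cyclobutyl on an aromatic carbon. Within the data shown here, the only measured step, no change at the digits printed from compound 1 to compound 2 (within the scatter), puts hydrogen in place of methyl on an aromatic carbon, so it does not cover this swap. Among the measured compounds shown here, no measured compound carries a 3-(aminomethyl)oxetan-3-yl group, which leaves the estimate as a judgement from the structural change alone. A downward step is expected, estimated as a number 1.00 log units lower from compound 1 to compound 3 (beyond the scatter). For compound 3, the estimate is 7.8, with an expected range of 7.2 to 8.4.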

Compound 3, acid dissociation constant: 7.9
Compound 3: the middle estimate sits 0.10 log units below what was measured; the measured number falls inside the stated range.
By their numbers in this assay, from the lowest: compound 3; then compounds 1 and 2 (each within the scatter of the next).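

Among these compounds, this is the first change here whose step lies beyond the scatter: in this assay, 3-(aminomethyl)oxetan-3-yl in place of 1-(aminomethyl)cyclobutyl gives a number 0.90 log units lower from compound 1 to compound 3 (beyond the scatter). The two groups hold the same number of heavy atoms, and the swap places an oxygen in the four-membered ring. Nothing measured here explains the shift. The compounds shown leave open whether the same step would appear without the methyl group. They also leave open how a six-membered tetrahydropyran ring or a longer aminoethyl chain would read.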